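Working notes: from compound 2 to compound 3

The compounds below may be only part of what the source reports. "The series", "measured", "known", "first", "only" and "open" are said of these compounds alone.

Of the compounds shown here, two have been measured so far, compound 1 (`CCCC(=O)OCSc1ccccc1C(=O)N[C@H]1CCC[C@@H]1C(N)=O`) and compound 2 (`CCCC(=O)OCSc1ccccc1C(=O)NCC(=O)N(C)C`). In an ADME assay on CEM-SS cells (Homo sapiens) for cytotoxicity, read by XTT assay, with a stated time of 6 days (on this read-out lower numbers stand for higher toxicity in this test and higher numbers for lower toxicity in this test), compound 1 gives 31.2 uM; 43.3 uM (2 entries) across its repeat entries. In this assay, among the measured compounds shown here, compound 2 gives 38.3 uM as its only number, and one further entry for it carries no single number. The two compounds therefore lie within the usual scatter of each other.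

The next compound to read is compound 3 (`CCCC(=O)OCSc1ccccc1C(=O)NC`). The change from compound 2 is hydrogen in place of dimethylcarbamoyl on a saturated chain carbon bound to an amide-type nitrogen and amounts to hydrogen in place of dimethylcarbamoyl on a saturated chain carbon bound to an amide-type nitrogen. The same difference can be read as (dimethylcarbamoyl)methyl to methyl. For the measured compounds named here, no measured pair isolates this change, so its size in this assay is an expectation only: no step beyond the scatter, and no favoured direction. That expectation rests on compound 2 at 38.3 uM and compound 1 at 31.2 uM; 43.3 uM (2 entries) as the only measured reference points. The estimated outcome is a 1.1-fold lower number from compound 2 to compound 3 (0.03 log units; within the scatter) in this series. For compound 3 the expected value is 36 uM with an estimated range of 15 uM to 85 uM in this read-out.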

Compound 3, half-maximal toxic concentration: 5.7 uM
Estimate against measurement, compound 3: 6.3-fold (0.80 log units) above, and the stated range ends above it.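

In this assay, hydrogen in place of dimethylcarbamoyl on a saturated chain carbon bound to an amide-type nitrogen gives a 6.7-fold lower number from compound 2 to compound 3 (0.83 log units; beyond the scatter), so this position does bear on the read-out, and the change goes toward higher toxicity in this test. Among the compounds shown here, compound 1 and compound 2 lay within the scatter of each other despite their different groups on the amide-type nitrogen, so they gave no sign of such sensitivity, and compound 3 is the first to separate from them through a single change. The step is also wider than the spread seen between repeat entries of a single compound: the several entries of compound 1 in this assay, 31.2 uM; 43.3 uM (2 entries)

One step cannot tell whether the lower number follows from the loss of the dimethylcarbamoyl group itself or from what remains once (dimethylcarbamoyl)methyl has become methyl, and the data give no cause for it. Ethyl or a longer alkyl chain in place of methyl, or a carboxylic acid in place of dimethylcarbamoyl, would show whether the size of the group or its carbonyl-bearing end goes with the read-out.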